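Replacing a sulfonamide by a carbamate on an indane core

This account rests on a few compounds, and the source may have more. Where it says the series, first, only, none or still open, it means among the compounds named here.

Measured compounds:
Compound 1 `Cc1cccc(C(=O)Nc2ccc3c(c2)CC(NS(=O)(=O)c2ccccc2)C3)c1-c1ccc(Cl)cc1`: 100 nM
Compound 2 `Cc1cccc(C(=O)Nc2ccc3c(c2)CC(NS(=O)(=O)c2cccs2)C3)c1-c1ccc(F)cc1`: 50 nM
Compound 3 `Cc1cccc(C(=O)Nc2ccc3c(c2)CC(NS(=O)(=O)c2cccs2)C3)c1-c1ccc(Cl)cc1`: 120 nM

The three measured compounds share one core and were tested in an assay on isolated protein for inhibition of microsomal triglyceride transfer protein large subunit (Homo sapiens); on this read-out lower numbers stand for stronger inhibition and higher numbers for weaker inhibition. Compound 3 gives 120 nM, the highest of the three numbers; compound 1 sits closest to it, the step being a 1.2-fold higher number from compound 1 to compound 3 (0.08 log units; within the scatter), while compound 2 lies furthest away, with a 2.4-fold higher number from compound 2 to compound 3 (0.38 log units; beyond the scatter).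

Compound 4 `COC(=O)NCC1Cc2ccc(NC(=O)c3cccc(C)c3-c3ccc(Cl)cc3)cc2C1` has not yet been measured. It differs from compound 3 in one place: ((methoxycarbonyl)amino)methyl in place of ((thiophen-2-yl)sulfonyl)amino on a saturated ring carbon. Neither measured step bears on this change. The step from compound 1 to compound 3 concerns the aromatic group on the sulfonyl sulfur, and the step from compound 2 to compound 3 concerns a halogen on an aromatic carbon; both keep the sulfonylamino group that compound 4 loses. Among the compounds with values here, no measured pair informs the exchange of a sulfonamide for a carbamate on the saturated ring carbon, so the size and direction of the step in this assay are open. On that basis compound 4 is expected to give 150 nM, between 30 nM and 800 nM, which corresponds to an estimated step of a 1.3-fold higher number from compound 3 to compound 4 (0.10 log units; within the scatter).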

Compound 4, half-maximal inhibitory concentration: 100 nM
Compound 4: middle estimate off by 1.5-fold (0.18 log units), on the high side; measured number inside the range.
By their numbers in this assay, from the lowest: compounds 2, 1, 4 and 3 (each within the scatter of the next, the first and the last beyond it).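

At the saturated ring carbon, the sulfonylamino group can give way to ((methoxycarbonyl)amino)methyl in this assay with no step beyond the scatter (a 1.2-fold lower number from compound 3 to compound 4 (0.08 log units; within the scatter)), and the same holds against the phenyl sulfonyl compound (no change at the digits printed from compound 1 to compound 4 (within the scatter)). The earlier steps shown here varied only the group on the sulfonyl sulfur or the halogen, whereas these show that the whole sulfonyl unit, with its aromatic ring, can be exchanged for an open-chain group of fewer heavy atoms and the number stays within the scatter. No supporting data are available to account for this outcome.

The exchange alters both the linking atoms and the terminal group, so the contribution of each stays unresolved, as does the carbamate's behaviour alongside the fluoro group of compound 2. From the compounds shown here alone, it is also open how a free amine, a carboxylic acid or a longer chain on the carbamate oxygen would fare at this ring carbon.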